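Fluoro for Hydrogen on the Aromatic Ring of Compound 1

The compounds below may be only part of what the source reports. "The series", "measured", "known", "first", "only" and "open" are said of these compounds alone.

Compound 1 `CC1(C)COc2ccccc2C1O`, compound 2 `CC1(C)COc2ccccc2C1N` and compound 3 `COc1cccc2c1C(O)C(C)(C)CO2` share one core and were tested in an assay on BTI cells for inhibition of Amine oxidase [flavin-containing] B (Homo sapiens), read by fluorescence, with a stated time of 20 min, tested at 1 uM; on this read-out lower numbers stand for less inhibition and higher numbers for more inhibition at the one concentration tested (going by the name of the read-out). In this assay compound 1 gives 8%, compound 2 gives 3.7% and compound 3 gives 5.3%. Compound 1 has the highest of the three numbers, yet both steps away from it stay within the scatter: a number 4.3 percentage points lower from compound 1 to compound 2 (within the scatter), and a number 2.7 percentage points lower from compound 1 to compound 3 (within the scatter). Compound 4 `CC1(C)COc2ccc(F)cc2C1O` differs from compound 1 by a single change: fluoro in place of hydrogen on an aromatic carbon. Among the compounds with values here, no measured step exchanges hydrogen for fluoro. The nearest comparison is the step to compound 3, in which methoxy in place of hydrogen on an aromatic carbon gave a number 2.7 percentage points lower from compound 1 to compound 3 (within the scatter); the step to compound 2, amino in place of hydroxy on a saturated ring carbon, was likewise within the scatter. Since every measured change on this core left this assay essentially unmoved, no step beyond the scatter is expected for compound 4 either. Compound 4 is estimated at 7%, with a range from 1% to 15%. This amounts to an expected a number 1 percentage points lower from compound 1 to compound 4 (within the scatter).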

Compound 4, a percentage reported as inhibition, at one concentration (the size of the read-out at that concentration, not a potency): 8.3%
The estimate for compound 4 lay 1.3 percentage points below the measured number; low and high end bracket the measured number.
By their numbers in this assay, from the lowest: compounds 2, 3, 1 and 4 (each within the scatter of the next).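

In this assay, fluoro in place of hydrogen on an aromatic carbon that is meta to a fused ring and para to a fused ring gives a number 0.3 percentage points higher from compound 1 to compound 4 (within the scatter). This adds a second aromatic replacement of hydrogen to the methoxy step, a number 2.7 percentage points lower from compound 1 to compound 3 (within the scatter), and although the two groups sit on different aromatic carbons, neither step leaves the scatter. Nothing available explains the result for fluoro at this position.

On these data alone, whether a larger group on this same aromatic carbon, such as a benzyloxy group, a carboxylic acid or a longer alkyl chain, would move the number beyond the scatter remains open. So does whether chloro or a nitrile on this carbon would behave as fluoro does here.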